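This account rests on a few compounds, and the source may have more. Where it says the series, first, only, none or still open, it means among the compounds named here.

Three compounds of the shared core have a reading in a functional assay on THP-1 cells (Homo sapiens) for inhibition, read by sulforhodamine B assay, with a stated time of 48 h; on this read-out higher numbers stand for weaker inhibition and lower numbers for stronger inhibition. Compound 1 `COc1ccc(C(O)(Cc2ccc(F)cc2)c2cccc3ccccc23)c(OC)c1OC` gives 5860 nM in this assay. Compound 2 `COc1ccc(/C(=N/O)c2cccc3ccccc23)c(OC)c1OC` gives only a limit of the assay in this assay, > 20000 nM. Compound 3 `COc1ccc(C(c2ccc(OCC(=O)O)cc2)c2cccc3ccccc23)c(OC)c1OC` likewise gives only a limit, > 20000 nM. Compound 2 therefore stands at the limit of > 20000 nM in this assay, at which 2 of the 3 values shown sit, and no number is known for it. Compound 4 `CCOC(=O)/C=C/CO/N=C(/c1ccc(OC)c(OC)c1OC)c1cccc2ccccc12` differs from compound 2 in one place: 3-(ethoxycarbonyl)prop-2-en-1-yl in place of hydrogen on an oxygen. For the measured compounds named here, no measured step covers a change of this kind, so its direction is open. The step expected is an at least 1.3-fold lower number from compound 2 to compound 4 (0.12 log units; that floor lies within the scatter), small and not beyond the scatter, with a fair chance that only a limit is reported again. For compound 4 the estimate in this assay is 15000 nM, expected between 4000 nM and 50000 nM.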

Compound 4, half-maximal inhibitory concentration: > 20000 nM
Compound 4 ended at the assay's limit; the forecaster's own chance of this, stated with the estimate: 55%; at least 1.3-fold (0.12 log units) between middle value and limit.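

No step can be read between compound 2 and compound 4, as both give only a limit: the limit of > 20000 nM in this assay, at which 3 of the 4 values shown sit.

The compounds shown leave open whether 3-(ethoxycarbonyl)prop-2-en-1-yl in place of hydrogen on an oxygen changes the reading at all, and in which direction.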